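This account rests on a few compounds, and the source may have more. Where it says the series, first, only, none or still open, it means among the compounds named here.

Compound 1 `O=C(O)CCCC(=O)Nc1cc(Nc2cccc(Br)c2)ncn1` carries a carboxylic acid at the end of its amide chain. In an assay for inhibition of Receptor tyrosine-protein kinase erbB-3 variant L858R (Homo sapiens), read by mobility shift assay, with a stated time of 10 min (a higher number here means a weaker inhibitor, a lower number a stronger inhibitor), compound 1 gives > 10000 nM, which is a limit of the assay and not a measured number. Compound 1 thus sits at the limit of > 10000 nM in this assay, at which 1 of the 2 values shown sits. Compound 2 `CCOC(=O)CCC(=O)Nc1cc(Nc2cccc(Br)c2)ncn1` differs from it only at the chain end, and in this assay compound 2 gives 1350 nM. The step of an at least 7.4-fold lower number from compound 1 to compound 2 (0.86 log units; beyond the scatter) concerns the chain and leaves the aromatic ring untouched.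

Compound 3 `COc1cccc(Nc2cc(NC(=O)CCCC(=O)O)ncn2)c1` keeps the acid chain of compound 1 and changes only the aromatic ring: methoxy in place of bromo on an aromatic carbon. No measured step touches this part of the molecule, so the two numbers shown say nothing about the size or direction of this change in this assay. Since compound 3 retains the acid chain and compound 1 sits at the limit of > 10000 nM in this assay, at which 1 of the 2 values shown sits, compound 3 is expected to remain a weak inhibitor, and the step that the limit leaves unreadable from compound 1 to compound 3 is expected to stay within the scatter. The estimated value for compound 3 in this assay is 20000 nM, in a range from 5000 nM to 80000 nM, with a strong chance that only a limit is reported again.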

Compound 3, half-maximal inhibitory concentration: 31 nM
Compound 3: middle estimate off by 650-fold (2.81 log units), on the high side, outside the stated range (below it).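

With the chain left untouched, replacing bromo by methoxy on this aromatic carbon, meta to a large group, gives an at least 320-fold lower number from compound 1 to compound 3 (2.50 log units; beyond the scatter) in this assay. So far only the chain end had been seen to move the result, and this step shows that the aromatic ring can also change it strongly, even with the carboxylic acid chain in place: compound 3 carries that same chain and gives 31 nM, so the chain alone does not hold a compound of this kind at weak inhibition. Compound 1 stands at a limit and not at a number, so the step gives only a lower bound on the true difference: the limit of > 10000 nM in this assay, at which 1 of the 3 values shown sits.

The compounds shown leave open whether the gain comes from the arrival of methoxy or the departure of bromo, and a hydroxy, a methyl or a chloro on the same aromatic carbon would help to separate the two. On these data alone, it also remains open whether the 3-methoxyphenyl group would keep this strength with the ethoxycarbonyl chain end of compound 2, or with a longer chain.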